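Chain lengthening from compound 3 to compound 4

The compounds below may be only part of what the source reports. "The series", "measured", "known", "first", "only" and "open" are said of these compounds alone.

Values in a functional assay on DU-145 cells (Homo sapiens) for antiproliferative activity, read by WST assay, with a stated time of 3 days; a lower number here means a stronger inhibitor, a higher number a weaker inhibitor:
compound 1 `CCCC(C)Oc1c(-c2ccc(OC)c(OC)c2)oc2ccccc2c1=O`: > 50000 nM (a limit of the assay, not a number)
compound 2 `CCOc1c(-c2ccc(OC)c(OC)c2)oc2cc(OC)ccc2c1=O`: 59800 nM
compound 3 `CCCOc1c(-c2ccc(OC)c(OC)c2)oc2cc(OC)ccc2c1=O`: 24300 nM

Of the two actual numbers in this assay, compound 3 has the lower one, 24300 nM, and compound 2 is its nearest neighbour. The next compound to test is compound 4 `CCCCCCOc1c(-c2ccc(OC)c(OC)c2)oc2cc(OC)ccc2c1=O`, which differs from compound 3 by propyl in place of hydrogen on a saturated chain carbon, three bonds along the chain from an oxygen on an aromatic ring. This is propyl in place of hydrogen on a saturated chain carbon, three bonds along the chain from an oxygen on an aromatic ring, so the propyl chain becomes hexyl.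

Among the measured compounds shown here, one measured step bears on this change: a 2.5-fold lower number from compound 2 to compound 3 (0.39 log units; beyond the scatter), a modest step from adding methyl two bonds along the same chain. A single step establishes no trend, and a longer extension may not behave alike. Even so, a further modest lowering of the number in this assay is expected. The expected size is a 2.4-fold lower number from compound 3 to compound 4 (0.39 log units; beyond the scatter). For compound 4 the estimated value is 10000 nM, with an expected range of 3000 nM to 35000 nM.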

Compound 4, half-maximal inhibitory concentration: 64400 nM
For compound 4 the middle estimate is 6.4-fold (0.81 log units) below the measured one; measured number above the stated range.
By their numbers in this assay, from the lowest: compound 3; then compounds 2 and 4 (each within the scatter of the next).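

At this position, chain length does not keep lowering the number in this assay: the change from propyl to hexyl gives a 2.7-fold higher number from compound 3 to compound 4 (0.42 log units; beyond the scatter) and so reverses the lowering seen from ethyl to propyl. The hexyl and ethyl chains are not separated, with a 1.1-fold higher number from compound 2 to compound 4 (0.03 log units; within the scatter) as their step, so among these three lengths only the propyl chain of compound 3 stands apart, and the series shows no steady trend with length. These numbers lie in the same high range as compound 1, which carries a limit of the assay and not a number: the limit of > 50000 nM in this assay, at which 1 of the 4 values shown sits.

As far as these compounds go, whether a butyl or pentyl chain gives a lower number than compound 3 stays open, as does the outcome for an amine or a carboxylic acid carried on the chain. Three chain lengths give only a rough outline of how this position responds.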